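The compounds below may be only part of what the source reports. "The series", "measured", "known", "first", "only" and "open" are said of these compounds alone.

Compound 3, `Cc1cc(-c2ccccc2)n(/C(N)=N/S(=O)(=O)c2cc(C)c(Cl)cc2SCc2ccc(Cl)cc2)n1`, carries a 4-chlorobenzyl group on the sulfur of the shared core. In a functional assay on HCT-116 cells (Homo sapiens) for cytotoxicity, read by MTT assay, with a stated time of 72 h (a higher number here means a weaker inhibitor, a lower number a stronger inhibitor), compound 3 gives 7000 nM. Compound 1, `Cc1cc(-c2ccccc2)n(/C(N)=N/S(=O)(=O)c2cc(C)c(Cl)cc2SCc2ccc(C(F)(F)F)cc2)n1`, bears a trifluoromethyl on that outer ring and gives 7000 nM, so that no change at the digits printed from compound 1 to compound 3 (within the scatter). Compound 2, `Cc1cc(-c2ccccc2)n(/C(N)=N/S(=O)(=O)c2cc(C)c(Cl)cc2SCc2ccccc2)n1`, has only hydrogen there and gives 10000 nM; a 1.4-fold lower number from compound 2 to compound 3 (0.15 log units; within the scatter). Compound 3 therefore sits level with compound 1, the two together holding the lowest numbers of the three, with compound 2 the furthest away, though no gap among these three compounds exceeds the scatter.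

Compound 4, `Cc1cc(-c2ccccc2)n(/C(N)=N/S(=O)(=O)c2cc(C)c(Cl)cc2SCc2ccccc2Cl)n1`, differs from compound 3 by 2-chlorophenyl in place of 4-chlorophenyl on a saturated chain carbon bound to a sulfur. For the measured compounds named here, none of the measured steps shifts a chloro from one position on this outer ring to another; the three steps known, a 1.4-fold higher number from compound 1 to compound 2 (0.15 log units; within the scatter), no change at the digits printed from compound 1 to compound 3 (within the scatter) and a 1.4-fold lower number from compound 2 to compound 3 (0.15 log units; within the scatter), all exchange one substituent for another in a single position and all stay within the scatter. What is known, then, is that the outer ring has tolerated three different substituents without a step beyond the scatter, and nothing bears directly on moving the chloro. On that basis compound 4 is expected to show no change at the digits printed from compound 3 to compound 4 (within the scatter), that is, no step beyond the scatter in this assay. Compound 4 is estimated at 7000 nM, with a range from 3500 nM to 14000 nM.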

Compound 4, half-maximal inhibitory concentration: 170000 nM
For compound 4 the middle estimate is 24-fold (1.39 log units) below the measured one, outside the stated range (above it).
By their numbers in this assay, from the lowest: compounds 1, 3 and 2 (each within the scatter of the next); then compound 4.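

Moving the chloro from 4-chlorobenzyl to 2-chlorobenzyl on the sulfur of the shared core gives a 24-fold higher number from compound 3 to compound 4 (1.39 log units; beyond the scatter) in this assay, the first step at this position that lies beyond the scatter, so the outer ring, which had taken hydrogen, chloro and trifluoromethyl without such a step, proves sensitive to where the chloro stands. Compound 4 stands apart from the other two compounds as well, with a 17-fold higher number from compound 2 to compound 4 (1.23 log units; beyond the scatter) and a 24-fold higher number from compound 1 to compound 4 (1.39 log units; beyond the scatter) in the same assay, so adding a chloro to the plain benzyl group can move the number far or not at all, depending on where that chloro is placed. Nothing available here gives a reason for this large gap.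

The compounds shown leave open whether the step belongs to the chloro itself or would also follow a methyl or methoxy group in its place on the 2-chlorobenzyl group. They also leave open whether a longer chain between the sulfur and the chlorophenyl ring would keep the number of compound 4 or bring it back towards that of compound 3.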